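Benzylamine series: chloro for methyl on the benzyl ring

The compounds below may be only part of what the source reports. "The series", "measured", "known", "first", "only" and "open" are said of these compounds alone.

Measured so far:
compound 1 `CNCc1c(OC)cc(Oc2cccc(Nc3ccccc3)c2)cc1OC`, 8930 nM
compound 2 `COc1cc(Oc2cccc(Nc3ccccc3)c2)cc(OC)c1CNCc1ccc(C)cc1`, 5400 nM

In a functional assay on HCT-15 cells (Homo sapiens) for inhibition, read by MTT assay, with a stated time of 72 h (a higher number here means a weaker inhibitor, a lower number a stronger inhibitor), compound 2 gives the lowest of the two numbers, but the step of a 1.7-fold lower number from compound 1 to compound 2 (0.22 log units; within the scatter) lies within the scatter, so no order between compound 1 and compound 2 is established. Compound 3 `COc1cc(Oc2cccc(Nc3ccccc3)c2)cc(OC)c1CNCc1ccc(Cl)cc1` differs from compound 2 by chloro in place of methyl on an aromatic carbon. For the measured compounds named here, no measured step touches this position; the only step known changes the chain carbon bound to the amine nitrogen. Without a comparable step, the expectation for compound 3 is a change no larger than the scatter, a 1.2-fold lower number from compound 2 to compound 3 (0.08 log units; within the scatter), giving an estimated 4500 nM with a range from 2000 nM to 12000 nM.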

Compound 3, half-maximal inhibitory concentration: 4850 nM
Estimate against measurement, compound 3: 1.1-fold (0.03 log units) below; low and high end bracket the measured number.
By their numbers in this assay, from the lowest: compounds 3, 2 and 1 (each within the scatter of the next).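

In this assay, for the compounds shown here, chloro in place of methyl on the aromatic carbon para to a large group gives a 1.1-fold lower number from compound 2 to compound 3 (0.05 log units; within the scatter) and so gives the first reading at this position, with no change beyond the scatter. Set against the hydrogen of compound 1, the 4-chlorophenyl on the chain carbon bound to the amine nitrogen gives a 1.8-fold lower number from compound 1 to compound 3 (0.27 log units; within the scatter) as a step that also stays within the scatter. Open, going by these compounds, is whether an amine or a carboxylic acid on this aromatic carbon would give a step beyond the scatter. No evidence on the origin of these numbers is at hand.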